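Trimming an Ethyl to a Methyl: Paw Edema Expected

The compounds below may be only part of what the source reports. "The series", "measured", "known", "first", "only" and "open" are said of these compounds alone.

Measured compounds:
compound 1, `Cc1ccc2oc(=O)n(CC(=O)NN)c2c1`: in a functional assay on the whole organism with Mus musculus as the target, read by paw edema, with a stated time of 360 min, at a dose of 50 mg/kg by the oral route (a lower number here means a stronger effect, a higher number a weaker effect of the compound at the dose given), compound 1 gives 101%
compound 2, `CCNC(=S)NNC(=O)Cn1c(=O)oc2ccc(C)cc21`: in this assay compound 2 gives 128%

Of the two numbers seen so far, compound 2 stands highest; its nearest neighbour is compound 1, which in this assay gives 101%. Going by the values given here, the one measured step, a number 27 percentage points higher from compound 1 to compound 2 (beyond the scatter), came from a group of five heavy atoms replacing a hydrogen atom on an amine nitrogen.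

Compound 3, `CNC(=S)NNC(=O)Cn1c(=O)oc2ccc(C)cc21`, has not yet been measured. It differs from compound 2 by hydrogen in place of methyl on a saturated chain carbon bound to an amide-type nitrogen. Read one bond further out, this is ethyl to methyl, or ethylamino to methylamino. Among the compounds with values here, no measured step touches this saturated chain carbon; the only step available, a number 27 percentage points higher from compound 1 to compound 2 (beyond the scatter), built the whole chain at once and is a larger change than the loss of one carbon. Compound 3 is therefore expected to move little from compound 2, with a step of a number 6 percentage points lower from compound 2 to compound 3 (within the scatter), within the scatter. The estimate for compound 3 in this assay is 122%, with a range from 100% to 142%.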

Compound 3, a percentage reported as activity, at one dose (the size of the read-out at that dose, not a potency): 189%
Beside the measured number, compound 3's estimate is 67 percentage points below it, outside the stated range (above it).
By their numbers in this assay, from the lowest: compound 1; then compound 2; then compound 3.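

In this assay, the loss of one carbon, ethyl to methyl on a saturated chain carbon bound to an amide-type nitrogen, gives a number 61 percentage points higher from compound 2 to compound 3 (beyond the scatter) and so moves the read-out toward a weaker effect at the dose given, in a step of greater size than the one that built the whole ethyl-bearing chain on compound 1. Against compound 1, the group with the methylamino end placed on the amine nitrogen gives a number 88 percentage points higher from compound 1 to compound 3 (beyond the scatter) in the same direction, which shows that this chain end is far from a silent part of the structure and that the size of the effect turns on a single carbon. Nothing at hand accounts for why one carbon at this place counts for so much.

Ethyl and methyl are only two points, so whether a longer chain such as propyl, or a plain amino group in place of methylamino, would continue this direction or break it remains open. On these data alone, it is also open whether the same sensitivity would hold with a carbonyl in place of the thiocarbonyl at this chain.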